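Adding chloro to compound 3

This account rests on a few compounds, and the source may have more. Where it says the series, first, only, none or still open, it means among the compounds named here.

In a functional assay on MDA-MB-231 cells (Homo sapiens) for inhibition, read by sulforhodamine B assay, with a stated time of 48 h (on this read-out lower numbers stand for stronger inhibition of growth and higher numbers for weaker inhibition of growth), compound 1 `Cc1nnc(-c2nn(-c3ccccc3)c(-c3ccccc3)c2C#N)c2cn(-c3ccccc3)nc12` reads > 100000 nM, which is a limit of the assay. Compound 2 `N#Cc1c(-c2nnc(O)c3nn(-c4ccc(Cl)cc4)cc23)nn(-c2ccccc2)c1-c1ccccc1` reads > 100000 nM, also a limit. For the measured compounds named here, compound 3 `N#Cc1c(-c2nnc(-c3ccccc3)c3nn(-c4ccccc4)cc23)nn(-c2ccccc2)c1-c1ccccc1` gives 8840 nM, the only true number so far. Compound 4 `N#Cc1c(-c2nnc(-c3ccccc3)c3nn(-c4ccc(Cl)cc4)cc23)nn(-c2ccccc2)c1-c1ccccc1` is compound 3 with chloro in place of hydrogen on an aromatic carbon, phenyl to 4-chlorophenyl: chloro in place of hydrogen on an aromatic carbon. Going by the values given here, the one measured step, an at least 11-fold lower number from compound 1 to compound 3 (1.05 log units; beyond the scatter), is large but concerns phenyl in place of methyl, so it does not cover this change. Its size rests on (the limit of > 100000 nM in this assay, at which 2 of the 3 values shown sit). The estimated step, a 1.5-fold lower number from compound 3 to compound 4 (0.17 log units; within the scatter), is expected to stay within the scatter. Compound 4 is expected at 6000 nM, with an estimated range of 2000 nM to 20000 nM.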

Compound 4, concentration for 50% growth inhibition: 6420 nM
Compound 4: middle estimate off by 1.1-fold (0.03 log units), on the low side; the range from low to high includes it.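

In this assay, chloro in place of hydrogen on this aromatic carbon gives a 1.4-fold lower number from compound 3 to compound 4 (0.14 log units; within the scatter), so this position accepts chloro without a change beyond the scatter. With 4-chlorophenyl in place, phenyl in place of hydroxy gives an at least 15-fold lower number from compound 2 to compound 4 (1.19 log units; beyond the scatter), which puts a second large step beside the one for phenyl in place of methyl, an at least 11-fold lower number from compound 1 to compound 3 (1.05 log units; beyond the scatter). Both sizes are only lower bounds, resting on a limit: the limit of > 100000 nM in this assay, at which 2 of the 4 values shown sit.

On these data alone, whether methoxy or an amine at the chloro position would move the number beyond the scatter remains open. Also open, as far as these compounds go, is whether a longer chain could stand in for the phenyl that replaces methyl and hydroxy.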